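Dropping the hydroxyl from the sulfanyl side chain

The source may report more compounds than this note shows. Statements on the series, on what has been measured and on what is new or still open speak of the compounds shown alone.

Measured compounds:
compound 1, `CC(C)c1n[nH]c2c(NCc3ccc(-c4ccccn4)cc3)nc(SCC(N)=O)nc12`, 192 nM
compound 2, `CC(C)c1n[nH]c2c(NCc3ccc(-c4ccccn4)cc3)nc(SC[C@H](O)CN)nc12`, 63 nM
compound 3, `CCC(CO)Sc1nc(NCc2ccc(-c3ccccn3)cc2)c2[nH]nc(C(C)C)c2n1`, 255 nM

In a functional assay on HT cells (Homo sapiens) for antiproliferative activity, read by fluorescence, with a stated time of 72 h (on this read-out lower numbers stand for stronger inhibition of growth and higher numbers for weaker inhibition of growth), compound 2 stands lowest of the three numbers, with compound 1 giving 192 nM and compound 3 giving 255 nM, both beyond the scatter of compound 2. The unmeasured compound 4, `CC(C)c1n[nH]c2c(NCc3ccc(-c4ccccn4)cc3)nc(SCCN)nc12`, is reached from compound 2 by aminomethyl in place of 2-amino-1-hydroxyethyl on a saturated chain carbon bound to a sulfur; the nitrogen of the chain stays while the oxygen goes. Among the compounds with values here, two steps bear on this. The step of a 3.0-fold lower number from compound 1 to compound 2 (0.48 log units; beyond the scatter) shows that bringing in the 3-amino-2-hydroxypropyl chain lowered the number against the carbamoylmethyl chain, and the step of a 4.0-fold higher number from compound 2 to compound 3 (0.61 log units; beyond the scatter) shows that replacing it by 1-(hydroxymethyl)propyl, which keeps an oxygen but has no nitrogen, raised it again. Neither step removes the oxygen while keeping the nitrogen, so compound 4 is expected to sit near compound 2, with a modest rise at most: the expected step is a 1.6-fold higher number from compound 2 to compound 4 (0.20 log units; within the scatter). Compound 4 is therefore estimated at 100 nM, between 40 nM and 250 nM.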

Compound 4, concentration for 50% growth inhibition: 22 nM
The estimate for compound 4 lay 4.5-fold (0.66 log units) above the measured number, outside the stated range (below it).
By their numbers in this assay, from the lowest: compound 4; then compound 2; then compounds 1 and 3 (each within the scatter of the next).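

In this assay, going from the 3-amino-2-hydroxypropyl chain to the 2-aminoethyl chain on the sulfur lowered the number rather than raising it (a 2.9-fold lower number from compound 2 to compound 4 (0.46 log units; beyond the scatter)), so neither the hydroxyl nor its defined stereocentre is needed for strong growth inhibition here. Compound 4 also stands clearly apart from the compounds carrying the 1-(hydroxymethyl)propyl chain (a 12-fold lower number from compound 3 to compound 4 (1.06 log units; beyond the scatter)) and the carbamoylmethyl chain (an 8.7-fold lower number from compound 1 to compound 4 (0.94 log units; beyond the scatter)), and it has the lowest number of the four. Nothing measured here accounts for this gain.

The compounds shown leave open whether a longer chain such as 3-aminopropyl, or a dimethylamino group at the chain end, would hold or lower this number. They also do not show how a simple 2-hydroxyethyl chain or a carboxylic acid would compare at this position.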